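The source may hold more compounds than are shown below. What is called first, only, known or untested is meant among the compounds shown, and "the series" means these compounds.

Measured so far:
- compound 1 `Clc1cccc(Cl)c1Cc1nnc(Nc2ccc(COCc3ccoc3)cc2)o1`: 21000 nM
- compound 2 `Clc1cccc(Cl)c1Cc1nnc(Nc2ccc(COCc3ccncc3)cc2)o1`: 81000 nM

Two compounds have been run in an ADME assay on MT2 cells (Homo sapiens) for cytotoxicity, read by MTT assay; a lower number here means that less compound is tolerated, a higher number that more compound is tolerated. Compound 2 stands highest of the two numbers there, the nearest being compound 1; the step between them, a 3.9-fold higher number from compound 1 to compound 2 (0.59 log units; beyond the scatter), is modest but beyond the scatter, and it consists of a single exchange of the aromatic group that sits on the methylene bound to the ether oxygen.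

Compound 3 `Clc1cccc(Cl)c1Cc1nnc(Nc2ccc(COCc3ccco3)cc2)o1` is the next compound, not yet measured. Its difference from compound 2: furan-2-yl in place of pyridin-4-yl on a saturated chain carbon bound to an oxygen on a saturated carbon

For the measured compounds named here, the only measured step that bears on this change is a 3.9-fold higher number from compound 1 to compound 2 (0.59 log units; beyond the scatter), which ran in the other direction: a five-membered furan was replaced by pyridin-4-yl and the number rose. Compound 3 puts a furan back in place of pyridin-4-yl, though attached through a different ring position (furan-2-yl rather than furan-3-yl). A partial or full reversal of that step is therefore expected, giving a lower number in this assay; the estimated step is a 3.2-fold lower number from compound 2 to compound 3 (0.51 log units; beyond the scatter). For compound 3 the expected value is 25000 nM, with a range of 10000 nM to 65000 nM.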

Compound 3, half-maximal cytotoxic concentration: 12000 nM
For compound 3 the middle estimate is 2.1-fold (0.32 log units) above the measured one, within the range that was stated.
By their numbers in this assay, from the lowest: compounds 3 and 1 (each within the scatter of the next); then compound 2.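

At this place, on a saturated chain carbon bound to an oxygen on a saturated carbon, a second furan now gives the same picture in this assay: the change to furan-2-yl gives a 6.8-fold lower number from compound 2 to compound 3 (0.83 log units; beyond the scatter), so the high number of compound 2 is set against two furans rather than one. The two furans are not separated from each other, as the exchange of furan-3-yl for furan-2-yl gives a 1.8-fold lower number from compound 1 to compound 3 (0.24 log units; within the scatter), and the point of attachment of the furan ring therefore makes no readable difference here; among these three compounds pyridin-4-yl alone stands apart, and none goes against that. Nothing at hand explains the gap between pyridin-4-yl and the furans.

The compounds shown leave open whether the higher number in this assay goes with the six-membered ring or with the ring nitrogen, as pyridin-4-yl differs from both furans in both respects; a phenyl group or pyridin-3-yl at this place would separate the two. Also open, on these data alone, is whether the same order holds on any core other than the one shared by these three compounds.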